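This account rests on a few compounds, and the source may have more. Where it says the series, first, only, none or still open, it means among the compounds named here.

In a physicochemical assay, read by spectrophotometry, with a stated time of 30 min (a higher number here means a weaker inhibitor, a lower number a stronger inhibitor), compound 2 `O=C(CC(c1ccc(Cl)cc1)c1c[nH]c2ccccc12)c1c(O)c2ccccc2oc1=O` gives 46.4 ug/mL and compound 1 `O=C(CC(c1ccccc1Cl)c1c[nH]c2ccccc12)c1c(O)c2ccccc2oc1=O` gives 39.6 ug/mL, two values within the scatter of each other, while compound 3 `O=C(CC(c1c(Cl)cccc1Cl)c1c[nH]c2ccccc12)c1c(O)c2ccccc2oc1=O` gives 13.5 ug/mL. Compound 4 `O=C(CC(c1ccc(F)cc1)c1c[nH]c2ccccc12)c1c(O)c2ccccc2oc1=O` differs from compound 2 by fluoro in place of chloro on an aromatic carbon, para to a large group. Among the measured compounds shown here, no measured step exchanges one halogen for another. The closest evidence is the shift of chloro in a 1.2-fold higher number from compound 1 to compound 2 (0.07 log units; within the scatter). The larger steps of a 2.9-fold lower number from compound 1 to compound 3 (0.47 log units; beyond the scatter) and a 3.4-fold lower number from compound 2 to compound 3 (0.54 log units; beyond the scatter) both end in a 2,6-dichlorophenyl group, which is absent here. No step beyond the scatter is expected in this assay, and the estimated change is a 1.1-fold lower number from compound 2 to compound 4 (0.04 log units; within the scatter). Compound 4 is estimated at 42 ug/mL, with an expected range of 20 ug/mL to 85 ug/mL.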

Compound 4, half-maximal inhibitory concentration: 47.4 ug/mL
Beside the measured number, compound 4's estimate is 1.1-fold (0.05 log units) below it; low and high end bracket the measured number.
By their numbers in this assay, from the lowest: compound 3; then compounds 1, 2 and 4 (each within the scatter of the next).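

In this assay, among the compounds shown here, fluoro in place of chloro on an aromatic carbon, para to a large group, is the first halogen exchange and falls within the scatter (a 1.0-fold higher number from compound 2 to compound 4 (0.01 log units; within the scatter)). Compound 4 also lies within the scatter of the 2-chlorophenyl compound (a 1.2-fold higher number from compound 1 to compound 4 (0.08 log units; within the scatter)), while the 2,6-dichlorophenyl group stays apart (a 3.5-fold higher number from compound 3 to compound 4 (0.55 log units; beyond the scatter)). Nothing available explains the result. Open, going by these compounds, is whether an amine or a methoxy group at this place would separate from compound 2 in this assay. Also open, on these data alone, is whether a 2,6-difluorophenyl group would match compound 3.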